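A few compounds are considered here, and "the series" means these few. Any claim that something is new, unique, unknown or untested is made for them only; others in the source may bear on it.

Measured compounds in the series:

- compound 1, `COc1ccc(OC)c(/C=C/c2nnc(Nc3ccc(Cl)cc3)o2)c1`: "not determined" (no result reported) in a functional assay on HOP-92 cells (Homo sapiens) for antiproliferative activity, read by sulforhodamine B assay, with a stated time of 48 h; on this read-out lower numbers stand for stronger inhibition of growth and higher numbers for weaker inhibition of growth
- compound 2, `COc1ccc(OC)c(/C=C/C(=O)N/N=C/c2ccc(Cl)cc2)c1`: 58900 nM

Compound 1 carries no number in this assay; only its structure is at hand. Compound 2 therefore stands alone on the numbers: in this assay compound 2 gives 58900 nM, and with no second value there is nothing to rank it against within the set.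

The next member, compound 3, `COc1ccc(OC)c(/C=C/C(=O)N/N=C/c2ccccc2)c1`, has not been measured yet. Against compound 2 the change is hydrogen in place of chloro on an aromatic carbon, on an aromatic carbon of a six-membered aromatic ring of carbon only. For the measured compounds named here, no measured pair in the set shows the effect of such a change, so the size of the step can only be expected, not read off.

The expectation is a small step from compound 2 to compound 3, a 1.2-fold higher number from compound 2 to compound 3 (0.07 log units; within the scatter), toward weaker inhibition of growth if anything, most likely not beyond the usual scatter. For compound 3 the estimate in this assay is 70000 nM, with a range from 25000 nM to 200000 nM.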

Compound 3, concentration for total growth inhibition: 13300 nM
The estimate for compound 3 lay 5.3-fold (0.72 log units) above the measured number; the whole stated range lies above it.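

In this assay, the 4-chlorophenyl to phenyl change now has a measured size, with a 4.4-fold lower number from compound 2 to compound 3 (0.65 log units; beyond the scatter) and a shift toward stronger inhibition of growth. This position, on an aromatic carbon para to a large group, is therefore sensitive: exchanging one chloro for hydrogen is enough to move the read-out, and the chloro is not required for the growth inhibition seen with this scaffold. This rests on a single pair, and nothing at hand gives a reason for the direction or size of the step.

For the compounds shown here, compound 1 carries no number, so no step involving it can be read, and it remains unknown whether the same exchange would have a similar effect on the core of compound 1. As far as these compounds go, it also remains open whether the shift is specific to losing chloro or would recur with other groups on the same aromatic carbon, such as fluoro, an amine or a carboxylic acid, so a single exchange does not yet define a trend at this position.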